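Series notes: amide-linked bicyclic core, variation on the aryl nitrogen substituent

The source may hold more compounds than are shown below. What is called first, only, known or untested is meant among the compounds shown, and "the series" means these compounds.

Measured so far:
- compound 1 `Cn1ccc2c(Oc3ccc(NC(=O)c4cc5cccnc5n(-c5ccc(F)cc5)c4=O)cc3)ccnc21`: 260 nM
- compound 2 `Cn1ccc2c(Oc3ccc(NC(=O)c4cc5cccnc5n(-c5ccc(Br)cc5)c4=O)cc3)ccnc21`: "not determined" (no result reported)
- compound 3 `Cn1ccc2c(Oc3ccc(NC(=O)c4cc5cccnc5n(-c5ccc(Br)cc5F)c4=O)cc3)ccnc21`: "not determined" (no result reported)

In a functional assay on NCI-H460 cells (Homo sapiens) for antiproliferative activity, read by MTT assay, with a stated time of 72 h (on this read-out higher numbers stand for weaker inhibition and lower numbers for stronger inhibition), compound 1 gives 260 nM. Going by the values given here, for compound 2 this assay records "not determined" (no result reported), and for compound 3 likewise "not determined" (no result reported), so compound 3 stands without a number, as does compound 2; the only number in the set belongs to compound 1.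

Compound 4 `Cn1ccc2c(Oc3ccc(NC(=O)c4cc5cccnc5n(-c5ccc(C(F)(F)F)cc5Cl)c4=O)cc3)ccnc21` carries the change (2-chloro-4-(trifluoromethyl)phenyl in place of 4-bromo-2-fluorophenyl on an aromatic nitrogen). Among the compounds with values here, no step between measured compounds is available in this assay, and no number exists for compound 3, so the size and direction of this step cannot be read from the data; nothing beyond the scatter is assumed either way.

Within the data shown here, on the single number for compound 1 at 260 nM, compound 4 is expected near 300 nM, with a wide range from 70 nM to 1500 nM.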

Compound 4, half-maximal inhibitory concentration: 6950 nM
Compound 4: middle estimate off by 23-fold (1.36 log units), on the low side, outside the stated range (above it).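

In this assay the aryl group on the aromatic nitrogen proves sensitive to substitution: 2-chloro-4-(trifluoromethyl)phenyl in place of 4-fluorophenyl gives a 27-fold higher number from compound 1 to compound 4 (1.43 log units; beyond the scatter) in this series, a step beyond the scatter. Steps involving compound 2 or compound 3 cannot be read, since neither has a number. No measurement at hand bears on the reason for this loss.

Chlorine and trifluoromethyl enter together, so the share of each in the step remains open. Also open, going by these compounds, is how an unsubstituted phenyl, a methoxy or an amine on this aryl ring would read.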